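A few compounds are considered here, and "the series" means these few. Any claim that something is new, unique, unknown or untested is made for them only; others in the source may bear on it.

Compound 2 `N=C(N)Nc1cccc(C(=O)NCC(=O)N[C@@H](CC(=O)O)C(=O)Nc2cccc3ccccc23)c1` carries a naphthalen-1-yl group on an amide-type nitrogen. In an assay on a protein complex for binding affinity to integrin alpha-5/beta-1 (Homo sapiens), read by ELISA, with a stated time of 1 h (a higher number here means a weaker inhibitor, a lower number a stronger inhibitor), compound 2 gives 22 nM, and compound 1 `N=C(N)Nc1cccc(C(=O)NCC(=O)N[C@@H](CC(=O)O)C(=O)NCc2ccccc2)c1`, with benzyl at the same place, gives 31 nM; the step of a 1.4-fold lower number from compound 1 to compound 2 (0.15 log units; within the scatter) is within the scatter, so the two numbers cannot be ordered. Compound 3 `N=C(N)Nc1cccc(C(=O)NCC(=O)N[C@@H](CC(=O)O)C(=O)NCc2ccc(Cl)cc2)c1` differs from compound 2 by 4-chlorobenzyl in place of naphthalen-1-yl on an amide-type nitrogen. Among the measured compounds shown here, the 4-chlorobenzyl group shares its benzyl part with compound 1, and the single step bearing on this exchange was within the scatter, so the step of a 1.4-fold higher number from compound 2 to compound 3 (0.13 log units; within the scatter) is expected to be small. Compound 3 is therefore estimated at 30 nM, with a range from 12 nM to 75 nM.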

Compound 3, half-maximal inhibitory concentration: 48 nM
The estimate for compound 3 lay 1.6-fold (0.20 log units) below the measured number; the measured number falls inside the stated range.
By their numbers in this assay, from the lowest: compounds 2, 1 and 3 (each within the scatter of the next, the first and the last beyond it).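

In this assay, this amide-type nitrogen gives its first step beyond the scatter, though a modest one, when 4-chlorobenzyl replaces naphthalen-1-yl (a 2.2-fold higher number from compound 2 to compound 3 (0.34 log units; beyond the scatter)). Chloro in place of hydrogen on an aromatic carbon of the benzyl group gives no step that can be ordered (a 1.5-fold higher number from compound 1 to compound 3 (0.19 log units; within the scatter)). No measured evidence here bears on these numbers. On these data alone, what an amine or a carboxylic acid would give in place of the chloro stays open, as does a longer chain carrying the aromatic ring on that nitrogen.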